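A few compounds are considered here, and "the series" means these few. Any claim that something is new, unique, unknown or untested is made for them only; others in the source may bear on it.

Of the compounds shown here, three built on one shared core have been measured so far. Compound 1 `O=C1CSC(c2cccc(O)c2)N1CCN1CCCCC1` carries a 3-hydroxyphenyl group on a saturated ring carbon, compound 2 `O=C1CSC(c2ccc(O)cc2)N1CCN1CCCCC1` carries a 4-hydroxyphenyl group there, and compound 3 `O=C1CSC(c2ccc(F)cc2)N1CCN1CCCCC1` carries a 4-fluorophenyl group. In an ADME assay on Vero cells (Chlorocebus sabaeus) for cytotoxicity, read by neutral red uptake, tested at 3150 ug/mL (a lower number here means a stronger effect, a higher number a weaker effect of the compound at the concentration tested), compound 1 gives 11%, compound 2 gives 10% and compound 3 gives 11%. The three readings sit close together: a number 1 percentage points lower from compound 1 to compound 2 (within the scatter), no change at the digits printed from compound 1 to compound 3 (within the scatter) and a number 1 percentage points higher from compound 2 to compound 3 (within the scatter). Compound 3 therefore stands level with compound 1 and within the scatter of compound 2, so none of the three can be set apart from the others.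

The next compound, compound 4 `O=C1CSC(c2ccc(Cl)cc2)N1CCN1CCCCC1`, differs from compound 3 in one place: chloro in place of fluoro on an aromatic carbon. Within the data shown here, no measured step swaps one halogen for another, so the closest guide is the step from compound 2 to compound 3, where fluoro replaced hydroxy without moving the reading beyond the scatter, and the step from compound 1 to compound 3, which also stayed within it. With every change on this aromatic ring so far leaving the reading flat, no step beyond the scatter is expected in this assay. The step expected is no change at the digits printed from compound 3 to compound 4 (within the scatter). Compound 4 is therefore estimated to give 11%, with a likely range from 4% to 20%.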

Compound 4, a percentage reported as activity, at one concentration (the size of the read-out at that concentration, not a potency): 11%
The estimate for compound 4 equals the measured number at the digits printed; low and high end bracket the measured number.
By their numbers in this assay, from the lowest: compounds 2, 1, 3 and 4 (each within the scatter of the next).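

In this assay, a swap of one halogen for another, chloro in place of fluoro on an aromatic carbon para to a large group, gives no change at the digits printed from compound 3 to compound 4 (within the scatter) and so adds a direct halogen comparison at this position. Chloro in place of hydroxy at the same position gives a number 1 percentage points higher from compound 2 to compound 4 (within the scatter) in this assay, while the 4-chlorophenyl group in place of the 3-hydroxyphenyl group gives no change at the digits printed from compound 1 to compound 4 (within the scatter) on the same saturated ring carbon, so among compounds 1 to 4 the chloro group cannot be told apart from the fluoro or hydroxy groups at this single tested concentration. Nothing available here explains why these readings stay together.

The compounds shown leave open whether a very different group on this aromatic ring, such as an amine, a carboxylic acid or a nitrile, would also stay within the scatter. They also leave open whether a longer chain elsewhere on the shared core would move the reading, since every change shown here concerns the aromatic group alone.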